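A benzimidazole ether in place of a piperazine chain

This account rests on a few compounds, and the source may have more. Where it says the series, first, only, none or still open, it means among the compounds named here.

The series rests on a shared core, shown in compound 1 `COc1c(OCCCN2CCNCC2)cc(O)c2c(=O)cc(-c3ccccc3)oc12`, whose only number comes from a functional assay on A549 cells (Homo sapiens) for cytotoxicity, read by MTT assay, with a stated time of 48 h; on this read-out lower numbers stand for stronger inhibition and higher numbers for weaker inhibition: compound 1 gives 10100 nM. Two relatives were prepared as well. Compound 2 `O=c1cc(-c2ccccc2)oc2c(OCCNCCO)c(O)cc(O)c12` carries a different side chain on the same core, and in this assay compound 2 is recorded as "not determined" (no result reported). Compound 3 `CNCCOc1c(O)cc(O)c2c(=O)cc(-c3ccccc3)oc12` likewise has no result, since in this assay compound 3 stands at "not determined" (no result reported). Among the measured compounds shown here, compound 1 is therefore the only member with a measured half-maximal inhibitory concentration, and it marks the sole reference point.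

Compound 4 `COc1c(OCc2nc3ccccc3[nH]2)cc(O)c2c(=O)cc(-c3ccccc3)oc12` has not yet been tested. It differs from compound 1 in one place: 1H-benzimidazol-2-yl in place of 2-(piperazin-1-yl)ethyl on a saturated chain carbon bound to an oxygen on an aromatic ring. The 2-(piperazin-1-yl)ethyl group leaves and the 1H-benzimidazol-2-yl group enters on the saturated chain carbon bound to an oxygen on the aromatic ring.

For the measured compounds named here, no measured pair in this set shows how such an exchange moves the readout, so the expectation rests on compound 1 alone. Compound 4 is estimated at 7000 nM, with a range from 1800 nM to 28000 nM. The expected step of a 1.4-fold lower number from compound 1 to compound 4 (0.16 log units; within the scatter) is small, toward slightly stronger inhibition, and is not expected to exceed the usual scatter by much.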

Compound 4, half-maximal inhibitory concentration: > 100000 nM
Compound 4: a limit, no number; the forecaster's own chance of this, stated with the estimate: 15%; middle value at least 14-fold (1.15 log units) away from the limit.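

In this assay compound 4 stands at > 100000 nM, which is a limit of the assay and not a number. The exchange of 2-(piperazin-1-yl)ethyl for 1H-benzimidazol-2-yl on a saturated chain carbon bound to an oxygen on an aromatic ring gives an at least 9.9-fold higher number from compound 1 to compound 4 (0.99 log units; beyond the scatter), toward weaker inhibition, and so shows what compound 1 alone could not: the read-out responds to what is carried at this place, and this change lowers the inhibition beyond the scatter. The full size of that loss stays unknown, and the step can be read only as a lower bound: the limit of > 100000 nM in this assay, at which 1 of the 4 values shown sits.

The compounds shown do not separate the loss of the piperazine from the arrival of the benzimidazole, and compounds 2 and 3 offer no number against which their side chains could be read. Going by these compounds, it remains open whether a (1H-benzimidazol-2-yl)propyl chain, which would keep the longer chain, or a 3-(dimethylamino)propyl chain, which would replace the piperazine with a simple amine, would stay closer to compound 1.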